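From azetidin-1-yl to (2-methoxyphenyl)amino on the shared core

This account rests on a few compounds, and the source may have more. Where it says the series, first, only, none or still open, it means among the compounds named here.

In a functional assay on ECa-109 cells for inhibition, with ECa-109 cell line (Homo sapiens) as the target, read by sulforhodamine B assay (a higher number here means a weaker inhibitor, a lower number a stronger inhibitor), compound 1 (`O=C1C=C(N2CCC2)C(=O)c2c1nc1n2[C@H]2OC[C@@H](O)[C@H]2OC1`) gives > 16000 nM, which is a limit and not a number. Compound 1 thus sits at the limit of > 16000 nM in this assay, at which 1 of the 3 values shown sits. Compound 2 (`O=C1C(Nc2ccc(Br)cc2)=CC(=O)c2c1nc1n2[C@H]2OC[C@@H](O)[C@H]2OC1`) gives 1980 nM and compound 3 (`Cc1ccc(NC2=CC(=O)c3c(nc4n3[C@H]3OC[C@@H](O)[C@H]3OC4)C2=O)cc1C`) gives 4090 nM, and both of these are measured numbers. Compound 4 (`COc1ccccc1NC1=CC(=O)c2nc3n(c2C1=O)[C@H]1OC[C@@H](O)[C@H]1OC3`) differs from compound 1 as follows: (2-methoxyphenyl)amino in place of azetidin-1-yl on a double-bonded ring carbon. Among the compounds with values here, the only measured step, a 2.1-fold higher number from compound 2 to compound 3 (0.32 log units; beyond the scatter), is modest and beyond the scatter. It compares two aromatic groups on the amine nitrogen, so it bears on the spread among such compounds and does not measure the loss of azetidin-1-yl. The expected change is an at least 5.3-fold lower number from compound 1 to compound 4 (0.72 log units; beyond the scatter), toward a stronger inhibitor. For compound 4 the estimated value is 3000 nM, with an expected range of 1000 nM to 10000 nM.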

Compound 4, half-maximal inhibitory concentration: > 4000 nM
Compound 4: a limit, no number; the forecaster's own chance of this, stated with the estimate: 10%; middle value at least 1.3-fold (0.12 log units) from the limit.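

Within the data shown here, compound 1 gives > 16000 nM, a limit, and no step to compound 4 can be read. Compound 4 gives > 4000 nM, also a limit. Still open, as far as these compounds go, is whether (2-methoxyphenyl)amino in place of azetidin-1-yl changes inhibition on the shared core at all.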